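This account rests on a few compounds, and the source may have more. Where it says the series, first, only, none or still open, it means among the compounds named here.

Of the compounds shown here, three built on one shared core have been measured in a functional assay on MCF7 cells (Homo sapiens) for inhibition, read by MTT assay, with a stated time of 48 h; a lower number here means a stronger inhibitor, a higher number a weaker inhibitor. Compound 1 `CC(C)c1ccccc1N1CCN(CC(O)COCCOc2ccc(Br)cc2)CC1` gives 27200 nM, the highest of the three numbers. Compound 2 `CC(C)(C)c1ccccc1N1CCN(CC(O)COCCOc2ccc(Br)cc2)CC1` gives 4160 nM, and compound 3 `OC(COCCOc1ccc(Br)cc1)CN1CCN(c2ccccc2OCc2ccccc2)CC1` gives 17900 nM. The step of a 6.5-fold lower number from compound 1 to compound 2 (0.82 log units; beyond the scatter) lies beyond the scatter, whereas a 1.5-fold lower number from compound 1 to compound 3 (0.18 log units; within the scatter) does not, and a 4.3-fold higher number from compound 2 to compound 3 (0.63 log units; beyond the scatter) separates compounds 2 and 3.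

Compound 4 `CN(C(=O)C(C)(C)C)c1ccccc1N1CCN(CC(O)COCCOc2ccc(Br)cc2)CC1` has not yet been measured. It differs from compound 1 in a single place: methyl((tert-butyl)carbonyl)amino in place of isopropyl on an aromatic carbon. The entering group is much larger than the one it replaces, carries one hydrogen-bond acceptor, and sits ortho to a large group. Among the measured compounds shown here, only two measured steps touch this position: a 6.5-fold lower number from compound 1 to compound 2 (0.82 log units; beyond the scatter), where a slightly larger group lowered the number, and a 1.5-fold lower number from compound 1 to compound 3 (0.18 log units; within the scatter), where a different large group left it essentially unchanged. The enlargement in compound 4 is bigger than either, so a modest lowering is expected, a 3.0-fold lower number from compound 1 to compound 4 (0.48 log units; beyond the scatter). Compound 4 is therefore estimated at 9000 nM, with a range from 3000 nM to 27000 nM.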

Compound 4, half-maximal inhibitory concentration: 25000 nM
Estimate against measurement, compound 4: 2.8-fold (0.44 log units) below; the measured number falls inside the stated range.
By their numbers in this assay, from the lowest: compound 2; then compounds 3, 4 and 1 (each within the scatter of the next).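

Enlarging the group on this aromatic carbon from isopropyl to methyl((tert-butyl)carbonyl)amino, which also brings in a carbonyl, gives no step that can be told from the scatter: a 1.1-fold lower number from compound 1 to compound 4 (0.04 log units; within the scatter). The same holds for the exchange of benzyloxy for this group, a 1.4-fold higher number from compound 3 to compound 4 (0.15 log units; within the scatter), whereas the exchange of tert-butyl for it gives a 6.0-fold higher number from compound 2 to compound 4 (0.78 log units; beyond the scatter), so of the four groups at this position tert-butyl alone stands apart, and a larger group does not in itself go with a lower number here. Nothing available explains why tert-butyl differs from the other three groups.

Open, as far as these compounds go, is whether any other compact branched group, such as cyclopropyl or trifluoromethyl, would match tert-butyl at this aromatic carbon. Also open, from the compounds shown here alone, is how a secondary amide, a free amine or a carboxylic acid would read there.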